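This account rests on a few compounds, and the source may have more. Where it says the series, first, only, none or still open, it means among the compounds named here.

Of the compounds shown here, two have been measured so far in an ADME assay on microsomes from liver (Rattus norvegicus) for metabolic stability, read by LC-MS, tested at 1 uM; a lower number here means that the compound disappears faster, a higher number that the compound lasts longer. Compound 1 (`Cc1cccc(Oc2nn(C(C)(C)C)c3ncnc(N)c23)c1`) lasts only 0.07 h there, whereas compound 2 (`Nc1ncnc2c1c(Nc1cccc(Cl)c1)nn2CC1CCNCC1`) reaches 0.333 h and so stands higher of the two, by a gap beyond the usual scatter. Compound 3 (`Cc1cccc(Sc2nn(CC3CCNCC3)c3ncnc(N)c23)c1`) keeps the (piperidin-4-yl)methyl group of compound 2 and differs on an aromatic carbon: (3-methylphenyl)sulfanyl in place of (3-chlorophenyl)amino on an aromatic carbon with (3-methylphenyl)sulfanyl in place of (3-chlorophenyl)amino. For the measured compounds named here, no measured pair isolates this exchange, so the expectation in this assay rests on just two values and remains loose. A small fall is expected, not clearly beyond the scatter, with compound 1 at 0.07 h marking the low side seen so far. The estimated change is a 1.7-fold lower number from compound 2 to compound 3 (0.22 log units; within the scatter) and would remain modest. Compound 3 is expected to show a half-life of 0.2 h within an estimated range from 0.07 h to 0.5 h when measured.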

Compound 3, half-life: 0.433 h
For compound 3 the middle estimate is 2.2-fold (0.34 log units) below the measured one; the range from low to high includes it.
By their numbers in this assay, from the lowest: compound 1; then compounds 2 and 3 (each within the scatter of the next).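

In this assay, (3-methylphenyl)sulfanyl in place of (3-chlorophenyl)amino on the aromatic carbon gives a 1.3-fold higher number from compound 2 to compound 3 (0.11 log units; within the scatter) while the (piperidin-4-yl)methyl group stays the same. This is the first step shown at this position, and it shows that the exchange, which also goes from one hydrogen-bond donor to none, leaves the half-life within the scatter. Nothing available bears on the reason for this result.

The exchange alters the linking atom and the substituent on the aromatic ring together, so the step cannot assign any share of the outcome to either change, and a pair with only one of them altered would be needed to separate them. Also open, as far as these compounds go, is how a methylene link at this position, or a longer chain in place of the (piperidin-4-yl)methyl group, would read in this assay on the same core.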